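From 3-chlorophenyl to 4-hydroxyphenyl on a weak inhibitor

The compounds below may be only part of what the source reports. "The series", "measured", "known", "first", "only" and "open" are said of these compounds alone.

In a functional assay on HeLa cells (Homo sapiens) for inhibition, read by MTT assay, with a stated time of 72 h (a lower number here means a stronger inhibitor, a higher number a weaker inhibitor), compound 1 (`COc1cc(NC(C)CCCNC(=O)NNC(=O)Nc2cccc(C(F)(F)F)c2)c2ncccc2c1`) gives 4900 nM and compound 2 (`COc1cc(NC(C)CCCNC(=O)NNC(=O)Nc2cccc(Cl)c2)c2ncccc2c1`) gives 44000 nM, the higher of the two numbers, which makes compound 2 the weaker inhibitor. Compound 3 (`COc1cc(NC(C)CCCNC(=O)NNC(=O)Nc2ccc(O)cc2)c2ncccc2c1`) is the next to consider, with 4-hydroxyphenyl in place of 3-chlorophenyl on an amide-type nitrogen. Among the measured compounds shown here, the only measured step that bears on this is a 9.0-fold higher number from compound 1 to compound 2 (0.95 log units; beyond the scatter), a modest one with chloro in place of trifluoromethyl on an aromatic carbon. For the measured compounds named here, it shows that changing this aromatic group can move the number, but no measured compound carries a hydroxy group, so the direction remains open. A shift of similar size either way is possible, yet no step beyond the scatter is the central expectation. The estimated change is a 1.1-fold lower number from compound 2 to compound 3 (0.04 log units; within the scatter). For compound 3 the expected value is 40000 nM, within an estimated range of 10000 nM to 120000 nM.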

Compound 3, half-maximal inhibitory concentration: 85000 nM
Beside the measured number, compound 3's estimate is 2.1-fold (0.33 log units) below it; measured number inside the range.
By their numbers in this assay, from the lowest: compound 1; then compounds 2 and 3 (each within the scatter of the next).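

In this assay, 4-hydroxyphenyl in place of 3-chlorophenyl on the amide-type nitrogen gives a 1.9-fold higher number from compound 2 to compound 3 (0.29 log units; within the scatter) and so stays within the scatter, even though 4-hydroxyphenyl carries a hydrogen-bond donor and acceptor that 3-chlorophenyl does not. The same group in place of 3-(trifluoromethyl)phenyl gives a 17-fold higher number from compound 1 to compound 3 (1.24 log units; beyond the scatter) and is a large step, so at this position the trifluoromethyl compound, compound 1, is the one that stands apart from both others. Nothing measured here explains this difference.

Both the group and its place on the aromatic ring change in going to compound 3, and the compounds shown do not separate those two changes. A 4-chlorophenyl or 3-hydroxyphenyl group would help to separate them, while an amine such as 4-aminophenyl remains an open case.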